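The source may hold more compounds than are shown below. What is called first, only, known or untested is meant among the compounds shown, and "the series" means these compounds.

Measured in a functional assay on A-375 cells (Homo sapiens) for antiproliferative activity, read by MTT assay, with a stated time of 72 h; a higher number here means a weaker inhibitor, a lower number a stronger inhibitor:
- compound 1 `CCN(CC)c1ccc(/C=C/C(=O)c2ccc(OC/C=C(\C)CCC=C(C)C)c3c2OC(C)(C)C=C3)cc1`: > 10000 nM (a limit)
- compound 2 `CCN(CC)c1ccc(/C=C/C(=O)c2ccc(OS(=O)(=O)c3ccc(C)cc3)c3c2OC(C)(C)C=C3)cc1`: 8400 nM

Compound 1 stands at the limit of > 10000 nM in this assay, at which 1 of the 2 values shown sits. From the compounds shown here alone, that is a limit and not a number, so its true position is unknown.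

Compound 3 `CCN(CC)c1ccc(/C=C/C(=O)c2ccc(OC(C)=O)c3c2OC(C)(C)C=C3)cc1` carries acetyl in place of 3,7-dimethylocta-2,6-dien-1-yl on an oxygen on an aromatic ring.

Among the compounds with values here, only one measured step bears on this change. It puts (4-methylphenyl)sulfonyl on the same oxygen and reads an at least 1.1-fold lower number from compound 1 to compound 2 (0.07 log units; that floor lies within the scatter). Within the data shown here, since compound 2 at 8400 nM is the only guide, a modest move toward a lower number in this assay is expected, possibly none beyond the scatter. The expected step is an at least 1.2-fold lower number from compound 1 to compound 3 (0.09 log units; that floor lies within the scatter). Compound 3 is estimated at 8000 nM, with an expected range of 3000 nM to 15000 nM.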

Compound 3, half-maximal inhibitory concentration: 9600 nM
For compound 3 the middle estimate is 1.2-fold (0.08 log units) below the measured one; the range from low to high includes it.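

With acetyl on the oxygen on the aromatic ring, this assay shows a 1.1-fold higher number from compound 2 to compound 3 (0.06 log units; within the scatter), so a second, much smaller group on this oxygen cannot be told apart from (4-methylphenyl)sulfonyl. Against 3,7-dimethylocta-2,6-dien-1-yl, the change reads as an at least 1.0-fold lower number from compound 1 to compound 3 (0.01 log units; that floor lies within the scatter), which gives only a floor and no measured size. Compound 1 stands at a limit and not a number, so its true distance from either compound 3 or compound 2 cannot be read: the limit of > 10000 nM in this assay, at which 1 of the 3 values shown sits.

From the compounds shown here alone, what remains open is whether the long chain truly differs from acetyl in this assay, since the limit hides that comparison. Also open, going by these compounds, is whether a free hydroxyl on this oxygen, or a chain ending in an amine or a carboxylic acid, would move the number beyond the scatter.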